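Adding a methoxy to a very short-lived compound

The source may report more compounds than this note shows. Statements on the series, on what has been measured and on what is new or still open speak of the compounds shown alone.

Values so far in an ADME assay; on this read-out higher numbers stand for a longer-lived compound and lower numbers for a shorter-lived compound
- compound 1 `COc1ccc(C[S+]([O-])c2ncccc2C(=O)Nc2ccncc2)c(OC)c1C` gives 0.12 h
- compound 2 `COc1cc(OC)c(C[S+]([O-])c2ncccc2C(=O)Nc2ccncc2)cc1Br` gives 0.07 h
- compound 3 `COc1ccc(C[S+]([O-])c2ncccc2C(=O)Nc2ccncc2)c(OC)c1` gives < 0.02 h

For compound 3 the reading < 0.02 h is a limit and not a number. Compound 3 lies lower than both of the other measured compounds, so any rise from it would be easy to see. Compound 4 `COc1cc(OC)c(OC)cc1C[S+]([O-])c1ncccc1C(=O)Nc1ccncc1` differs from compound 3 by methoxy in place of hydrogen on an aromatic carbon and nothing else. Within the data shown here, two measured steps bear on this change. Hydrogen in place of methyl gave an at least 6.0-fold lower number from compound 1 to compound 3 (0.77 log units; beyond the scatter) and hydrogen in place of bromo gave an at least 3.5-fold lower number from compound 2 to compound 3 (0.54 log units; beyond the scatter) as the second case. Read backwards, a group in place of hydrogen raised the number both times. Neither group is methoxy, however, so these steps guide the direction better than the size. Compound 2 carries its bromo where the methoxy enters, and its 0.07 h is the nearer guide, so a modest rise in this assay is expected. The estimated change is an at least 2.5-fold higher number from compound 3 to compound 4 (0.39 log units; beyond the scatter) and no more than that. For compound 4 the expected value is 0.05 h within an estimated range of 0.02 h to 0.12 h in this measurement.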

Compound 4, half-life: < 0.02 h
Compound 4: only a limit was reported; the forecaster's own chance of this, stated with the estimate: 25%; middle value at least 2.5-fold (0.39 log units) away from the limit.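

In this assay compound 4 gives < 0.02 h and that reading is a limit, not a number. The step between compound 3 and compound 4 cannot be read, because both compounds rest on the same limit: the limit of < 0.02 h in this assay, at which 2 of the 4 values shown sit. Methoxy in place of bromo gave an at least 3.5-fold lower number from compound 2 to compound 4 (0.54 log units; beyond the scatter) and nothing shows a rise from methoxy here, so at this position the kind of group matters, and a group in place of hydrogen does not always lift the reading clear of the limit.

The compounds shown leave open how far apart compound 3 and compound 4 really lie, since neither has a number. They also leave open whether an amine, a hydroxyl or a longer chain such as ethoxy at this position would give a reading above the limit, as bromo does in compound 2.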